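This account rests on a few compounds, and the source may have more. Where it says the series, first, only, none or still open, it means among the compounds named here.

Among the compounds with values here, compound 1 `Clc1ccc(-c2nnc(-c3ccc(-n4cccc4)cc3)o2)cc1` is the only member of this set with a number in an ADME assay on A549 cells (Homo sapiens) for cytotoxicity, read by MTT assay, with a stated time of 72 h; on this read-out lower numbers stand for stronger inhibition and higher numbers for weaker inhibition; there compound 1 gives 256000 nM. Compound 2 `Cc1ccc(C)n1-c1ccc(C(=O)N/N=C/c2ccccc2[N+](=O)[O-])cc1` shows "not determined" (no result reported) in this assay, so it offers no point of comparison. Compound 3 `c1ccc(-c2nnc(-c3ccc(-n4cccc4)cc3)o2)cc1` differs from compound 1 by hydrogen in place of chloro on an aromatic carbon. Within the data shown here, no measured step covers this change. From the weak value of compound 1 alone, the step is expected to stay within the scatter, with no clear direction, so the estimated step is a 1.2-fold higher number from compound 1 to compound 3 (0.07 log units; within the scatter). Compound 3 is therefore estimated at 300000 nM in this assay, with a range from 120000 nM to 750000 nM.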

Compound 3, half-maximal inhibitory concentration: 256000 nM
The estimate for compound 3 lay 1.2-fold (0.07 log units) above the measured number; low and high end bracket the measured number.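

In this assay, within the data shown here, the change from 4-chlorophenyl to phenyl gives no change at the digits printed from compound 1 to compound 3 (within the scatter), the first measured step. On this aromatic carbon, para to a large group, chloro and hydrogen are therefore not told apart by this read-out, and compound 3 stays as weak as compound 1. No measured data on the compounds bear on this result. Open, going by these compounds, is whether an amine, a carboxylic acid or a longer chain at this position would give a different number. With only hydrogen and chloro shown here, the tolerance of this position to larger groups remains unknown.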